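From methoxy to methyl on compound 3

A few compounds are considered here, and "the series" means these few. Any claim that something is new, unique, unknown or untested is made for them only; others in the source may bear on it.

- compound 1 `Cc1ccc(/C=C/C(=O)Nc2nnc(-c3ccc(Cl)cc3)s2)cc1` gives 1.44 ug/mL
- compound 2 `Cc1ccc(/C=C/C(=O)Nc2nnc(-c3ccc(C)cc3)s2)cc1` gives 0.61 ug/mL
- compound 3 `COc1ccc(/C=C/C(=O)Nc2nnc(-c3ccccc3)s2)cc1` gives 0.83 ug/mL

These values come from a functional assay on MCF7 cells (Homo sapiens) for antiproliferative activity, read by MTT assay, with a stated time of 48 h (on this read-out lower numbers stand for stronger inhibition and higher numbers for weaker inhibition), and place compound 3 within the scatter of both compound 1 and compound 2. Compound 4 `Cc1ccc(/C=C/C(=O)Nc2nnc(-c3ccccc3)s2)cc1` follows from compound 3 by one change: methyl in place of methoxy on an aromatic carbon with methyl in place of methoxy on an aromatic carbon, para to a large group. Going by the values given here, the only measured step, a 2.4-fold lower number from compound 1 to compound 2 (0.37 log units; beyond the scatter) replaces chloro rather than methoxy, so it is a modest and indirect guide. No shift beyond the scatter is therefore expected, in either direction, in this assay and the estimated 1.0-fold lower number from compound 3 to compound 4 (0.02 log units; within the scatter) is small. The estimate for compound 4 is 0.8 ug/mL with an expected range from 0.4 ug/mL to 1.6 ug/mL on this read-out.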

Compound 4, half-maximal inhibitory concentration: 1.23 ug/mL
For compound 4 the middle estimate is 1.5-fold (0.19 log units) below the measured one; low and high end bracket the measured number.
By their numbers in this assay, from the lowest: compounds 2, 3, 4 and 1 (each within the scatter of the next, the first and the last beyond it).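

In this assay, methyl in place of methoxy at this position, para to a large group, stays within the scatter (a 1.5-fold higher number from compound 3 to compound 4 (0.17 log units; within the scatter)), so this read-out does not separate 4-methoxyphenyl from 4-methylphenyl here. Hydrogen in place of methyl (a 2.0-fold higher number from compound 2 to compound 4 (0.30 log units; within the scatter)) and hydrogen in place of chloro (a 1.2-fold lower number from compound 1 to compound 4 (0.07 log units; within the scatter)) also stay within it, which places compound 4 within the scatter of both ends of the one step that exceeds it. From the compounds shown here alone, whether an amine or a longer chain such as butoxy at the methoxy position would give a step beyond the scatter remains open. No measurement offers an explanation for these numbers.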